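The source may hold more compounds than are shown below. What is called first, only, known or untested is meant among the compounds shown, and "the series" means these compounds.

In an ADME assay on microsomes from liver (Rattus norvegicus) for metabolic stability (on this read-out lower numbers stand for a shorter-lived compound and higher numbers for a longer-lived compound), compound 1 `CC(C)(O)COc1ccc2c(Oc3ccc(Nc4nccc5[nH]cc(-c6ccc(F)cc6)c(=O)c45)cc3F)ccnc2c1` gives 4.14 h as the highest of three numbers. Compound 2 `O=c1c(-c2ccc(F)cc2)c[nH]c2ccnc(Nc3ccc(Oc4ccnc5cc(O)ccc45)c(F)c3)c12` gives 0.893 h and compound 3 `CC(O)COc1ccc2c(Oc3ccc(Nc4nccc5[nH]cc(-c6ccc(F)cc6)c(=O)c45)cc3F)ccnc2c1` gives 1.42 h on the same read-out. Compound 4 `CC(C)(O)COc1ccc2c(Oc3ccc(Nc4nccc5[nH]cc(-c6ccccc6)c(=O)c45)cc3F)ccnc2c1` has not yet been measured. Its change (hydrogen in place of fluoro on an aromatic carbon) puts hydrogen in place of fluoro on an aromatic carbon, turning 4-fluorophenyl to phenyl. The measured steps (a 4.6-fold lower number from compound 1 to compound 2 (0.67 log units; beyond the scatter); a 2.9-fold lower number from compound 1 to compound 3 (0.46 log units; beyond the scatter); a 1.6-fold higher number from compound 2 to compound 3 (0.20 log units; within the scatter)) all alter the chain on the oxygen and never this fluoro, so none of them sizes this change directly. Compound 1 sits at the top of the set (4.14 h), so the estimate leans slightly lower. No step beyond the scatter is expected (a 1.4-fold lower number from compound 1 to compound 4 (0.14 log units; within the scatter)). Compound 4 is expected at 3 h (estimated range 1.5 h to 5.5 h).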

Compound 4, half-life: 5.37 h
The estimate for compound 4 lay 1.8-fold (0.25 log units) below the measured number, and the stated range covers the measured number.
By their numbers in this assay, from the lowest: compounds 2 and 3 (each within the scatter of the next); then compounds 1 and 4 (each within the scatter of the next).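

In this assay, among these compounds, the change from 4-fluorophenyl to phenyl gives a 1.3-fold higher number from compound 1 to compound 4 (0.11 log units; within the scatter) and so gives the first reading at this end of the molecule: here, on a ring of carbon only, the fluoro can give way to hydrogen without a step beyond the scatter. This holds for one pair only, with the 2-hydroxy-2-methylpropyl chain on the oxygen. Nothing at hand accounts for this result. Still open, on these data alone, is how a chloro, a methoxy or a nitrile would read at this place, and whether the same swap holds with the 2-hydroxypropyl chain of compound 3.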